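This account rests on a few compounds, and the source may have more. Where it says the series, first, only, none or still open, it means among the compounds named here.

Measured so far:
compound 1, `COc1cccc(NC(=O)NC2CC(C)(C)Oc3ccc(Cl)cc32)c1` — in a functional assay (aorta) with Rattus norvegicus as the target (on this read-out higher numbers stand for an effect only at larger amounts of compound and lower numbers for an effect already at smaller amounts), compound 1 gives > 10000 nM, a limit of the assay and not a number;
compound 2, `COc1cccc(NC(=O)NC2CC(C)(C)Oc3ccc(Br)cc32)c1` — in this assay compound 2 gives > 10000 nM, again only a limit;
compound 3, `CC1(C)CC(NC(=O)Nc2ccccc2Cl)c2cc(Cl)ccc2O1` — in this assay compound 3 gives > 300000 nM, likewise a limit.

The change bromo in place of chloro on an aromatic carbon gives a step that the two limits leave unreadable from compound 1 to compound 2; both values sit at the limit of > 10000 nM in this assay, at which 2 of the 3 values shown sit, so its size cannot be read. The cores of compound 1 and compound 3 differ by 2-chlorophenyl in place of 3-methoxyphenyl on an amide-type nitrogen, and a step that the two limits leave unreadable from compound 1 to compound 3 is equally unreadable, one value at the limit of > 10000 nM in this assay, at which 2 of the 3 values shown sit, and the other at the limit of > 300000 nM in this assay, at which 1 of the 3 values shown sits.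

Compound 4, `CC1(C)CC(NC(=O)Nc2ccccc2Cl)c2cc(Br)ccc2O1`, is not yet measured. It differs from compound 3 by bromo in place of chloro on an aromatic carbon, the same change as between compound 1 and compound 2, made here on a core that already gives only a limit. Because compound 3 stands at the limit of > 300000 nM in this assay, at which 1 of the 3 values shown sits, the expected step is a number no higher from compound 3 to compound 4 (the limit leaves the size open), essentially nothing. Compound 4 is therefore estimated at 300000 nM in this assay, between 50000 nM and 1000000 nM, and most probably again only a limit will be reported.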

Compound 4, half-maximal effective concentration: > 30000 nM
Compound 4: only a limit was reported; the forecaster's own chance of this, stated with the estimate: 85%; the middle value does not contradict the limit.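

Compound 4 gives > 30000 nM, a limit and not a number. Its steps from compound 3 and from compound 2 cannot be read. The compounds shown leave open what size of effect, if any, either change has.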